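Acetyl for hydrogen: a repeated step in the series

A few compounds are considered here, and "the series" means these few. Any claim that something is new, unique, unknown or untested is made for them only; others in the source may bear on it.

Compound 1 `C=C1CC[C@@H]2[C@](C)(CO[Si](c3ccccc3)(c3ccccc3)C(C)(C)C)[C@H](OC(C)=O)CC[C@@]2(C)[C@@H]1C/C=C1/C(=O)OC[C@H]1O`, compound 2 `C=C1CC[C@@H]2[C@](C)(CO[Si](c3ccccc3)(c3ccccc3)C(C)(C)C)[C@H](O)CC[C@@]2(C)[C@@H]1C/C=C1/C(=O)OC[C@H]1O` and compound 3 `C=C1CC[C@@H]2[C@](C)(COC(C)=O)[C@H](O)CC[C@@]2(C)[C@@H]1C/C=C1/C(=O)OC[C@H]1O` have been run in a functional assay on MCF7 cells (Homo sapiens) for cytotoxicity, read by sulforhodamine B assay; a higher number here means that more compound is needed for the effect, a lower number that less compound is needed. In this assay compound 1 gives 7.53 uM, compound 2 gives 8.15 uM and compound 3 gives 18.3 uM. The change from compound 2 to compound 1 is acetyl in place of hydrogen on an oxygen on a saturated carbon, and it made a 1.1-fold lower number from compound 2 to compound 1 (0.03 log units; within the scatter). The difference between the cores of compound 3 and compound 2 is not broken down here. Compound 4 `C=C1CC[C@@H]2[C@](C)(COC(C)=O)[C@H](O)CC[C@@]2(C)[C@@H]1C/C=C1/C(=O)OC[C@H]1OC(C)=O` has not yet been run in this assay; it differs from compound 3 by acetyl in place of hydrogen on an oxygen on a saturated carbon, the same change at the same place as before. Because a 1.1-fold lower number from compound 2 to compound 1 (0.03 log units; within the scatter) stayed within the scatter, the step from compound 3 to compound 4 is expected to be about a 1.1-fold lower number from compound 3 to compound 4 (0.06 log units; within the scatter). Compound 4 is therefore estimated at 16 uM, most likely between 8 uM and 32 uM.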

Compound 4, concentration for half-maximal effect: 18.5 uM
Compound 4: the middle estimate sits 1.2-fold (0.06 log units) below what was measured, and the stated range covers the measured number.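

In this assay, acetyl in place of hydrogen on an oxygen on a saturated carbon gives a 1.0-fold higher number from compound 3 to compound 4 (0.00 log units; within the scatter), and the two steps on different cores do not differ: the same change on two cores in this assay, a 1.1-fold lower number (0.03 log units; within the scatter) from compound 2 to compound 1 and a 1.0-fold higher number (0.00 log units; within the scatter) from compound 3 to compound 4, 1.1-fold (0.04 log units) apart, within the scatter of two such steps. In these two cases the change carries from one core to the other and leaves the number within the scatter. For the compounds shown here, with only two steps, both in a single cell assay, this says nothing about other cores or other assays, and it does not explain why the number stays flat.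

The compounds shown leave open whether a larger ester on that oxygen, such as benzoyl or a longer acyl chain, would move the number beyond the scatter. An amine-bearing group there also remains untested in the compounds shown here.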